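From 4-methoxyphenyl to naphthalen-1-yl: a step without precedent

A few compounds are considered here, and "the series" means these few. Any claim that something is new, unique, unknown or untested is made for them only; others in the source may bear on it.

Of the compounds shown here, two with a shared core have been measured so far. In a functional assay on HL-60 cells (Homo sapiens) for inhibition, read by CCK-8 assay, with a stated time of 48 h, tested at 20 uM (a higher number here means more inhibition of growth at the concentration tested, a lower number less inhibition of growth), compound 1 `COc1ccc(Cc2nnc(NC(=O)/C(C#N)=C/c3ccccc3OS(=O)(=O)c3ccccc3[N+](=O)[O-])s2)cc1` gives 25% at the single concentration tested. Compound 2 `COc1ccc(Cc2nnc(NC(=O)/C(C#N)=C/c3ccccc3OS(=O)(=O)c3ccc(F)cc3)s2)cc1` gives 25% in the same test and so stands level with compound 1.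

Compound 3 `N#C/C(=C\c1ccccc1OS(=O)(=O)c1ccc(F)cc1)C(=O)Nc1nnc(Cc2cccc3ccccc23)s1` differs from compound 2 at the other end of the molecule. It carries naphthalen-1-yl in place of 4-methoxyphenyl on a saturated chain carbon bound to an aromatic carbon.

Among the measured compounds shown here, only one measured step exists (no change at the digits printed from compound 1 to compound 2 (within the scatter)), and it put 4-fluorophenyl in place of 2-nitrophenyl on a sulfonyl sulfur. For the measured compounds named here, that step lies elsewhere in the molecule, so it bears on the new change only indirectly, and no measured step covers this place. The data therefore point in neither direction, and no shift beyond the scatter is expected in this assay (a number 2 percentage points higher from compound 2 to compound 3 (within the scatter) is the estimated step), starting from compound 2 at 25% as the only anchor. For compound 3 the expected value is 27%, with an estimated range from 10% to 48% here.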

Compound 3, percent growth inhibition at one concentration: 12%
The estimate for compound 3 lay 15 percentage points above the measured number, within the range that was stated.
By their numbers in this assay, from the lowest: compound 3; then compounds 1 and 2 (each within the scatter of the next).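

In this assay, putting naphthalen-1-yl in place of 4-methoxyphenyl on a saturated chain carbon bound to an aromatic carbon gives a number 13 percentage points lower from compound 2 to compound 3 (beyond the scatter). This shows that growth inhibition at the single concentration tested responds to a change at this end of the molecule, whereas the change on the sulfonyl sulfur gave no change at the digits printed from compound 1 to compound 2 (within the scatter). The swap alters several things at once, since the entering group has two aromatic rings of carbon only and no hydrogen-bond acceptor, while the leaving group has one such ring and one acceptor, and nothing available explains the drop.

As far as these compounds go, a single step cannot show which of these differences matters, so it remains open whether a plain phenyl group, which has neither the second ring nor the methoxy oxygen, would stand with compound 2 or with compound 3. Also open, from the compounds shown here alone, is how naphthalen-2-yl, or a ring bearing an amine or a carboxylic acid on the same chain carbon, would fare in this assay.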